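The source may report more compounds than this note shows. Statements on the series, on what has been measured and on what is new or still open speak of the compounds shown alone.

Of the compounds shown here, three have so far been measured in a functional assay (aorta) with Oryctolagus cuniculus as the target; a higher number here means a weaker inhibitor, a lower number a stronger inhibitor. Compound 1 `COc1ccc([C@@H]2Cc3c(cccc3C(F)(F)F)N(C[C@@H]3CCCN3)C(=O)[C@@H]2OC(C)=O)cc1` gives 90 nM there. Compound 2 `COc1ccc([C@@H]2Cc3cc(OC)ccc3N(C[C@@H]3CCCN3)C(=O)[C@@H]2OC(C)=O)cc1`, built on a different core, gives 230 nM in this assay; the difference between the two cores is not broken down here. Compound 3 `COc1ccc([C@@H]2Cc3c(cccc3C(F)(F)F)N(C[C@@H]3CCCN3)C(=O)[C@@H]2O)cc1` gives 100 nM in this assay. Compound 3 arises from compound 1 by hydrogen in place of acetyl on an oxygen on a saturated carbon and the step reads a 1.1-fold higher number from compound 1 to compound 3 (0.05 log units; within the scatter), so the two numbers sit within the scatter of each other. Compound 2 holds the highest number of the three, and its gaps to compound 3 and to compound 1 both lie beyond the scatter.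

Compound 4 `COc1ccc([C@@H]2Cc3cc(OC)ccc3N(C[C@@H]3CCCN3)C(=O)[C@@H]2O)cc1` has not yet been measured in this assay. For the measured compounds named here, it arises from compound 2 by hydrogen in place of acetyl on an oxygen on a saturated carbon, which is the same change as the one from compound 1 to compound 3, at the same kind of place. The expectation rests on that single measured pair: because a 1.1-fold higher number from compound 1 to compound 3 (0.05 log units; within the scatter) lay within the scatter, the new step is expected to be of the same small size, a 1.1-fold higher number from compound 2 to compound 4 (0.04 log units; within the scatter). Compound 4 is accordingly estimated at 250 nM in this assay, with a likely range from 130 nM to 480 nM. Whether the change behaves alike on the core of compound 2 and on the core of compound 1 is not shown by any measured pair, so the range is kept wide.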

Compound 4, half-maximal inhibitory concentration: 1120 nM
Beside the measured number, compound 4's estimate is 4.5-fold (0.65 log units) below it; the whole stated range lies below it.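

In this assay the change from acetoxy to hydroxy does not keep one step size across the two cores: the same change on two cores in this assay, a 1.1-fold higher number (0.05 log units; within the scatter) from compound 1 to compound 3 and a 4.9-fold higher number (0.69 log units; beyond the scatter) from compound 2 to compound 4, 4.4-fold (0.64 log units) apart, beyond the scatter of two such steps. On the core of compound 2 the change reads a 4.9-fold higher number from compound 2 to compound 4 (0.69 log units; beyond the scatter), whereas on the core of compound 1 the two numbers sit within the scatter of each other, so for this series the size of the step on one core is no safe guide to its size on the other. For the compounds shown here, the finding rests on a single pair per core and shows only that the two steps differ; no measured pair breaks down the difference between the cores, so it does not show which part of that difference goes with the gap, nor how the change would behave on any third core.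

Open, as far as these compounds go, is whether a different group on the same oxygen, such as a methyl ether or a longer ester like propionyl or butyryl, would track the acetyl or the hydroxy on each core. Also open, from the compounds shown here alone, is whether an amine in place of that oxygen would show the same dependence on the core in this assay.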